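The source may hold more compounds than are shown below. What is called first, only, known or untested is meant among the compounds shown, and "the series" means these compounds.

Compound 3 `O=C(CCCCCc1cccc(C(F)(F)F)c1)N1CCOC1=O` is the anchor of this comparison. In an assay on HEK293 cells for inhibition of N-acylethanolamine-hydrolyzing acid amidase (Rattus norvegicus), read by LC-MS, with a stated time of 30 min (on this read-out lower numbers stand for stronger inhibition and higher numbers for weaker inhibition), compound 3 gives 58 nM, the lowest of the two numbers recorded. Compound 2 `CSc1cccc(CCCCCC(=O)N2CCOC2=O)c1` carries a methylsulfanyl group where a trifluoromethyl group stands in the anchor; in this assay compound 2 gives 12800 nM. Compound 1 `Cc1ccc(CCCCCC(=O)N2CCOC2=O)cc1C` gives > 20000 nM in this assay, which is a limit of the measurement and not a number. Among the compounds with values here, the single measured step, a 220-fold lower number from compound 2 to compound 3 (2.34 log units; beyond the scatter), shows how much the group on this aromatic carbon can shift the read-out.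

Compound 4 `Cc1cccc(CCCCCC(=O)N2CCOC2=O)c1` differs from compound 3 in one place: methyl in place of trifluoromethyl on an aromatic carbon. Within the data shown here, no measured pair covers exactly this exchange. The step from compound 2 to compound 3 went strongly in favour of trifluoromethyl over another small group on the same carbon, and compound 1, which carries methyl groups on its ring, sits at the limit of > 20000 nM in this assay, at which 1 of the 3 values shown sits. Taken together, the small methyl group is expected to move the number well upward from compound 3, beyond the scatter. Compound 4 is therefore expected to give about 4000 nM in this assay, with a plausible range from 600 nM to 20000 nM. That expectation amounts to a 69-fold higher number from compound 3 to compound 4 (1.84 log units; beyond the scatter).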

Compound 4, half-maximal inhibitory concentration: 350 nM
The estimate for compound 4 lay 11-fold (1.06 log units) above the measured number; measured number below the stated range.
By their numbers in this assay, from the lowest: compound 3; then compound 4; then compound 2. At a limit, above all of these: compound 1.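

Methyl in place of trifluoromethyl gives a 6.0-fold higher number from compound 3 to compound 4 (0.78 log units; beyond the scatter), so strong inhibition does not depend on trifluoromethyl alone, while methyl in place of methylsulfanyl gives a 37-fold lower number from compound 2 to compound 4 (1.56 log units; beyond the scatter), which makes methylsulfanyl, not methyl, the poor group among the three compared on this aromatic carbon. The ring is also sensitive to a further methyl group: hydrogen in place of that methyl gives an at least 57-fold lower number from compound 1 to compound 4 (1.75 log units; beyond the scatter), so a small addition elsewhere on the ring can matter more than the exchange of trifluoromethyl for methyl. The value of compound 1 is a limit of the assay and not a number: the limit of > 20000 nM in this assay, at which 1 of the 4 values shown sits.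

It remains open whether a chlorine atom, a methoxy group or a nitrile on this aromatic carbon would behave more like trifluoromethyl and methyl or more like methylsulfanyl, and what a shorter or longer chain would do to any of these compounds. The numbers rank the groups but give no reason for their order, so the cause of these differences stays unknown.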